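The compounds below may be only part of what the source reports. "The series", "measured", "known", "first", "only" and "open" are said of these compounds alone.

Compound 1 `c1ccc(C(c2c[nH]c3ccccc23)c2c[nH]c3ccccc23)cc1` gives 21800 nM
Compound 2 `COc1ccc(C(c2c[nH]c3ccc(Br)cc23)c2c[nH]c3ccc(Br)cc23)cc1` gives 5500 nM
Compound 3 `COc1ccc(C(c2c[nH]c3ccc(Br)cc23)c2c[nH]c3ccc(Br)cc23)cc1OC` gives 6100 nM

These values come from a functional assay on HeLa cells (Homo sapiens) for inhibition, read by MTT assay, with a stated time of 48 h; a lower number here means a stronger inhibitor, a higher number a weaker inhibitor. Compound 2 stands at the low end of the three numbers, together with compound 3, and the two cannot be told apart (a 1.1-fold higher number from compound 2 to compound 3 (0.04 log units; within the scatter)). Compound 1 has a clearly higher number, but it differs from compound 2 in more than one place, so that gap cannot be pinned on any single change.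

The next structure is compound 4 `Brc1ccc2[nH]cc(C(c3ccc4ccccc4c3)c3c[nH]c4ccc(Br)cc34)c2c1`, which has naphthalen-2-yl in place of 4-methoxyphenyl on a saturated chain carbon bound to two aromatic carbons. Among the compounds with values here, only one measured step touches this part of the molecule: methoxy in place of hydrogen on an aromatic carbon, going to compound 3 with 6100 nM and staying within the scatter. Within the data shown here, that is a much smaller edit than swapping the whole group, and no measured compound carries a second fused ring, so the evidence is thin. No clear shift in either direction is therefore expected, and the expected change is small (a 1.1-fold lower number from compound 2 to compound 4 (0.04 log units; within the scatter)). For compound 4 the estimated value is 5000 nM, with an expected range from 1800 nM to 14000 nM.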

Compound 4, half-maximal inhibitory concentration: 4300 nM
The estimate for compound 4 lay 1.2-fold (0.07 log units) above the measured number; measured number inside the range.
By their numbers in this assay, from the lowest: compounds 4, 2 and 3 (each within the scatter of the next); then compound 1.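

In this assay, within the data shown here, the earlier compounds showed only an added methoxy on the aromatic ring at this position, whereas here the whole group is exchanged: naphthalen-2-yl in place of 4-methoxyphenyl gives a 1.3-fold lower number from compound 2 to compound 4 (0.11 log units; within the scatter) and naphthalen-2-yl in place of 3,4-dimethoxyphenyl gives a 1.4-fold lower number from compound 3 to compound 4 (0.15 log units; within the scatter) on the saturated chain carbon bound to two aromatic carbons. Both steps remove every oxygen from this group and bring in a second six-membered aromatic ring, yet neither moves the number beyond the scatter, so on this shared core a methoxy group is not needed to keep the activity seen with compound 2 and compound 3. Nothing measured here explains why these different groups read alike.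

The compounds shown leave open whether this position would accept something of a different kind, such as an amine or a carboxylic acid on the aromatic ring, or a longer chain in its place. They also leave open how much of the gap to compound 1 belongs to the two bromines, since compound 1 differs from the others in more than one place.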